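Swapping the Nitrophenyl Ring for a Furan Ring

The source may report more compounds than this note shows. Statements on the series, on what has been measured and on what is new or still open speak of the compounds shown alone.

Measured so far:
- compound 1, `CC(C)(C)n1ncc(OCc2nnc(-c3ccc(Br)cc3)o2)c(Cl)c1=O`: 21.4 ug/mL
- compound 2, `CC(C)(C)n1ncc(OCc2nnc(-c3ccc([N+](=O)[O-])cc3)o2)c(Cl)c1=O`: > 300 ug/mL

In a functional assay on the whole organism for inhibition, with Mythimna separata as the target, with a stated time of 5 days (a higher number here means that more compound is needed for the effect, a lower number that less compound is needed), compound 1 gives 21.4 ug/mL. For compound 2 this assay reports only a limit, > 300 ug/mL. The single measured step, an at least 14-fold higher number from compound 1 to compound 2 (1.14 log units; beyond the scatter), ends at the limit of > 300 ug/mL in this assay, at which 1 of the 2 values shown sits, so compound 2 stands at the weak end of what is shown, with no exact number.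

Compound 3, `CC(C)(C)n1ncc(OCc2nnc(-c3ccco3)o2)c(Cl)c1=O`, carries a different ring at the same spot: furan-2-yl in place of 4-nitrophenyl on an aromatic carbon. Going by the values given here, the one measured step swapped only a substituent on the same ring, so it bears on this change loosely: it shows that this position is sensitive, but not how a furan-2-yl ring would fare. With compound 1 as the only numbered point of reference, the expectation for compound 3 is a step back toward lower numbers in this assay, an at least 4.2-fold lower number from compound 2 to compound 3 (0.63 log units; beyond the scatter), though a result that again stays at the limit cannot be ruled out. The estimate for compound 3 is therefore 70 ug/mL, with a range from 15 ug/mL to 300 ug/mL.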

Compound 3, half-maximal effective concentration: > 300 ug/mL
Compound 3 gave a limit, no number; the forecaster's own chance of this, stated with the estimate: 30%; middle value at least 4.2-fold (0.63 log units) from the limit.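

Among the three groups shown at this position, only 4-bromophenyl gives an exact number in this assay, and exchanging it for furan-2-yl brings an at least 14-fold higher number from compound 1 to compound 3 (1.14 log units; beyond the scatter). The large loss is therefore not tied to the nitro group alone: a five-membered aromatic ring with fewer heavy atoms and no nitro group also ends at the weak end of this assay. The step between compound 2 and compound 3 cannot be read, and neither compound can be ranked against the other: the limit of > 300 ug/mL in this assay, at which 2 of the 3 values shown sit.

As far as these compounds go, it remains open whether another group at this position, such as 4-chlorophenyl, unsubstituted phenyl or a phenyl ring carrying an amine, would also give an exact number. From the compounds shown here alone, it also remains open how far compound 2 and compound 3 lie beyond the limit.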